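Urea aryl swap on the dichlorinated thienopyrimidine-free core series

The source may hold more compounds than are shown below. What is called first, only, known or untested is meant among the compounds shown, and "the series" means these compounds.

Three compounds have numbers in a functional assay on HT-29 cells (Homo sapiens) for cytotoxicity, read by MTT assay, with a stated time of 72 h; a higher number here means a weaker inhibitor, a lower number a stronger inhibitor. Compound 1 `CN(C)CCCNc1nc(-c2ccc(NC(=O)Nc3ccccc3F)cc2)nc2ccsc12` gives 470 nM. Compound 2 `CN(C)CCCNc1nc(-c2ccc(NC(=O)Nc3ccc(F)cc3)cc2)nc2c(Cl)c(Cl)sc12` gives 430 nM. Compound 3 `CN(C)CCNc1nc(-c2ccc(NC(=O)Nc3ccc(F)cc3)cc2)nc2c(Cl)c(Cl)sc12` gives 890 nM, the highest of the three; its gap to compound 1 lies within the scatter, its gap to compound 2 beyond it. Within the data shown here, the only single-place step recorded is a 2.1-fold higher number from compound 2 to compound 3 (0.32 log units; beyond the scatter), which concerns the chain, not the urea.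

Compound 4 `CN(C)CCNc1nc(-c2ccc(NC(=O)Nc3ccccc3Cl)cc2)nc2c(Cl)c(Cl)sc12` differs from compound 3 by 2-chlorophenyl in place of 4-fluorophenyl on an amide-type nitrogen. Among the measured compounds shown here, no recorded step isolates a change on this urea aryl group: compound 1 and compound 2 differ there and at the core at once, and their values lie within the scatter of each other. With nothing bearing directly on the aryl swap, no step beyond the scatter is expected in this assay, and the estimate is anchored on compound 3. Compound 4 is expected to give 850 nM, within 350 nM to 2100 nM, an expected step of a 1.0-fold lower number from compound 3 to compound 4 (0.02 log units; within the scatter).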

Compound 4, half-maximal inhibitory concentration: 570 nM
Compound 4: middle estimate off by 1.5-fold (0.17 log units), on the high side, within the range that was stated.
By their numbers in this assay, from the lowest: compounds 2, 1, 4 and 3 (each within the scatter of the next, the first and the last beyond it).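

In this assay the urea aryl group now has its first isolated change: 2-chlorophenyl in place of 4-fluorophenyl on the amide-type nitrogen gives a 1.6-fold lower number from compound 3 to compound 4 (0.19 log units; within the scatter) with chain and core held fixed. The earlier pair, compound 1 and compound 2, changed this group and the core at once, so it could not show this. Here the two aryl groups are not told apart by this read-out on this chain and core, and no measurement bears on the reason for the result.

On these data alone, whether the swap behaves the same on the chain of compound 2 remains open. Also open, as far as these compounds go, is whether a halogen on this ring matters at all, which a plain phenyl or a pyridyl ring on the same nitrogen would address.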